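The source may report more compounds than this note shows. Statements on the series, on what has been measured and on what is new or still open speak of the compounds shown alone.

Compound 2 `N#C/C(=C\N1CCN(C(=O)c2ccco2)C1=S)C(N)=O` gives 7500 nM in a functional assay on KM12 cells (Homo sapiens) for inhibition, read by sulforhodamine B assay, with a stated time of 48 h (a higher number here means a weaker inhibitor of growth, a lower number a stronger inhibitor of growth), and this is the lowest of the two numbers measured; its nearest neighbour is compound 1 `N#C/C(=C\N1CCN(C(=O)c2ccco2)C1=S)C(=O)Nc1ccc(Cl)cc1`, which in this assay gives 16300 nM. For the measured compounds named here, the only measured step, a 2.2-fold lower number from compound 1 to compound 2 (0.34 log units; beyond the scatter), came from putting hydrogen in place of 4-chlorophenyl on an amide-type nitrogen. Compound 3 `N#C/C(=C\N1CCN(C(=O)c2ccco2)C1=S)C(=O)c1ccccc1` differs from compound 2 by phenyl in place of amino on a carbonyl carbon. Going by the values given here, this change adds an aromatic ring back onto the same part of the molecule, though on the carbonyl carbon rather than the nitrogen, and the one step available shows that carrying an aromatic ring there went with a higher number in this assay. On that basis, a modest rise beyond the scatter is expected for compound 3, on the order of a 1.6-fold higher number from compound 2 to compound 3 (0.20 log units; within the scatter). Compound 3 is therefore estimated at 12000 nM, with a likely range from 4000 nM to 40000 nM.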

Compound 3, concentration for 50% growth inhibition: 6500 nM
Compound 3: the middle estimate sits 1.8-fold (0.27 log units) above what was measured, and the stated range covers the measured number.
By their numbers in this assay, from the lowest: compounds 3 and 2 (each within the scatter of the next); then compound 1.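

In this assay, putting phenyl in place of amino on a carbonyl carbon gives a 1.2-fold lower number from compound 2 to compound 3 (0.06 log units; within the scatter), so carbamoyl and benzoyl cannot be told apart here. An aromatic ring at this place therefore does not by itself go with a higher number, something the earlier step could not show, and a 2.5-fold lower number from compound 1 to compound 3 (0.40 log units; beyond the scatter) sets compound 1 apart from compound 3 as well as from compound 2. Nothing available explains these results.

On these data alone, it remains open whether the higher number of compound 1 goes with the chlorine, the ring or the nitrogen joining that ring to the carbonyl, which a phenylamino or 4-chlorobenzoyl group could help separate. As far as these compounds go, how a methyl group or a hydroxyl group, which would make a carboxylic acid, would read on this carbonyl carbon also stays open.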